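The source may report more compounds than this note shows. Statements on the series, on what has been measured and on what is new or still open speak of the compounds shown alone.

Series notes, solubility. Compound 1 `COCCNC(=O)c1cn(-c2cccc3cc(Cc4cccc(C(F)(F)F)c4)sc23)nc1C` sits at a limit of a physicochemical assay for solubility, read by HPLC, at pH 6.8; on this read-out higher numbers stand for higher solubility and lower numbers for lower solubility: compound 1 gives < 0.1 ug/mL, a limit and not a number. Compound 2 `Cc1nn(-c2cccc3cc(Cc4cccc(C(F)(F)F)c4)sc23)cc1C(=O)NCCO` also returns a limit, < 0.1 ug/mL. Among the measured compounds shown here, compound 3 `COCCNC(=O)c1c(C)nn(-c2cccc3cc(Cc4cccc(C(F)(F)F)c4)sc23)c1C` gives 2.9 ug/mL, the only number in the set.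

The change from compound 1 to compound 2 is hydrogen in place of methyl on an oxygen on a saturated carbon; its step, a step that the two limits leave unreadable from compound 1 to compound 2, cannot be sized, since both ends sit at the limit of < 0.1 ug/mL in this assay, at which 2 of the 3 values shown sit. The cores of compound 1 and compound 3 differ by methyl in place of hydrogen on an aromatic carbon, with an at least 29-fold higher number from compound 1 to compound 3 (1.46 log units; beyond the scatter).

Compound 4 `Cc1nn(-c2cccc3cc(Cc4cccc(C(F)(F)F)c4)sc23)c(C)c1C(=O)NCCO` is unmeasured; its difference from compound 3 is hydrogen in place of methyl on an oxygen on a saturated carbon, the same change as from compound 1 to compound 2, at the same place. Given that the earlier step is unreadable, compound 4 is expected to stay near compound 3, with an estimated 1.0-fold higher number from compound 3 to compound 4 (0.01 log units; within the scatter). Compound 4 is estimated at 3 ug/mL, between 1 ug/mL and 9 ug/mL.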

Compound 4, solubility: 12 ug/mL
Estimate against measurement, compound 4: 4.0-fold (0.60 log units) below, and the stated range ends below it.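

In this assay, the change from 2-methoxyethyl to 2-hydroxyethyl on the core of compound 3 gives a 4.1-fold higher number from compound 3 to compound 4 (0.62 log units; beyond the scatter). Compound 1 and compound 2 both sit at a limit, so the same change has no readable size on their core, and one readable step does not show that it carries from one core to another: the limit of < 0.1 ug/mL in this assay, at which 2 of the 4 values shown sit. Methyl in place of hydrogen on an aromatic carbon gives an at least 120-fold higher number from compound 2 to compound 4 (2.07 log units; beyond the scatter), in the same direction as an at least 29-fold higher number from compound 1 to compound 3 (1.46 log units; beyond the scatter), though each step starts from a limit and their sizes cannot be compared.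

The compounds shown leave open how the core of compound 3 reads with an amine or a carboxylic acid in place of the hydroxy. As far as these compounds go, a longer chain in place of 2-hydroxyethyl also remains open.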